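Swapping an allyl for a phenyl on the enamine nitrogen

The compounds below may be only part of what the source reports. "The series", "measured", "known", "first", "only" and "open" are said of these compounds alone.

Measured compounds:
- compound 1, `CCN/C(SC)=C(/C#N)C(=O)Nc1ccc(OCC)cc1`: > 100000 nM
- compound 2, `C=CCN/C(SC)=C(/C#N)C(=O)Nc1ccc(OCC)cc1`: > 100000 nM
- compound 3, `CCOc1ccc(NC(=O)c2c(N)n[nH]c2Nc2ccccc2)cc1`: 67800 nM

In an ADME assay on TERT-RPE1 cells (Homo sapiens) for cytotoxicity, read by resazurin assay, with a stated time of 48 h (on this read-out lower numbers stand for stronger inhibition and higher numbers for weaker inhibition), compound 2 gives only a limit, > 100000 nM, so its true value is not known as a number. Compound 1 likewise stops at a limit in this assay, > 100000 nM. Compound 3, which carries an anilino group on a different core, gives a measured number in this assay, 67800 nM.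

Compound 4, `CCOc1ccc(NC(=O)/C(C#N)=C(\Nc2ccccc2)SC)cc1`, differs from compound 2 by phenyl in place of allyl on an amine nitrogen. Among the measured compounds shown here, the only measured step between single-point neighbours, a step that the two limits leave unreadable from compound 1 to compound 2, cannot be read because of the limit of > 100000 nM in this assay, at which 2 of the 3 values shown sit; it does not test an allyl-to-phenyl swap on the nitrogen either. Nothing measured therefore bears directly on the change to compound 4. Compound 3 shows that an anilino compound of this family can land in the weak range, so a modest shift at most is expected.

Compound 4 is estimated at 90000 nM in this assay, with a likely range from 35000 nM to 250000 nM. That estimate means a step of an at least 1.1-fold lower number from compound 2 to compound 4 (0.04 log units; that floor lies within the scatter), expected to stay within the scatter, with a real chance that compound 4 again reports only a limit.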

Compound 4, half-maximal inhibitory concentration: > 100000 nM
Compound 4 gave a limit, no number; the forecaster's own chance of this, stated with the estimate: 50%; at least 1.1-fold (0.04 log units) between middle value and limit.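

Compound 4 also stops at a limit, > 100000 nM, and not at a number. Among the compounds shown here, no step among compound 1, compound 2 and compound 4 can be read, because all three sit at the same limit: (the limit of > 100000 nM in this assay, at which 3 of the 4 values shown sit). From the compounds shown here alone, whether anilino in place of allylamino changes the result in this assay at all remains open.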